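The source may hold more compounds than are shown below. What is called first, only, known or untested is meant among the compounds shown, and "the series" means these compounds.

In a functional assay on OVCAR-3 cells (Homo sapiens) for antiproliferative activity, read by WST assay, with a stated time of 72 h, in the presence of a further agent that is not named here (on this read-out higher numbers stand for weaker inhibition and lower numbers for stronger inhibition), compound 1 (`CCCCCCCC/C=C/c1c(C)c(/C=C/CCCCCCCC)c2[n+](c1C)CCC2`) gives 700 nM and compound 2 (`CCCCCCCCCCc1c(C)c(CCCCCCCCCC)c2[n+](c1C)CCCCC2`) gives 800 nM, two numbers within the scatter of each other. For the measured compounds named here, compound 1 is therefore not separated from the only other measured member of the series. Going by the values given here, these two compounds differ in more than one place, so they offer no single-change step. The next compound to be read is compound 3 (`CCCCCCCC/C=C\c1c(C)c(/C=C/CCCCCCCC)c2[n+](c1C)CCC2`). Relative to compound 1, the change is this: the two compounds have the same atoms and bonds and differ only in configuration as drawn: 1 of 2 stereo elements differ; a double bond is drawn E in compound 1 and Z in compound 3. Among the compounds with values here, no measured pair isolates a change of double-bond configuration, so the direction of any shift cannot be derived from the data, and the expectation is anchored on compound 1 at 700 nM alone. The expected 1.1-fold higher number from compound 1 to compound 3 (0.06 log units; within the scatter) stays within the scatter. For compound 3 the estimated value is 800 nM, with an expected range from 350 nM to 1800 nM in this read-out.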

Compound 3, half-maximal inhibitory concentration: 500 nM
For compound 3 the middle estimate is 1.6-fold (0.20 log units) above the measured one; the measured number falls inside the stated range.
By their numbers in this assay, from the lowest: compounds 3, 1 and 2 (each within the scatter of the next).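

In this assay the series gains its first single-change step, and it isolates the configuration of one double bond: a 1.4-fold lower number from compound 1 to compound 3 (0.15 log units; within the scatter) is the whole of what that change shows. Within this pair, drawing this double bond Z rather than E is therefore not separated from leaving it E, so the read-out gives no preference for either configuration at this place. The comparison is free of any other structural change, which the pair of compound 1 and compound 2 could not offer: the fact that compounds 1 and 3 differ only in the configuration as drawn.

Still open, as far as these compounds go, is the second double bond, drawn E in both compound 1 and compound 3, including what a Z configuration there would give. Also open, from the compounds shown here alone, is whether an amine, a carboxylic acid or a longer chain in place of the chain carrying the changed double bond would give a number beyond the scatter.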